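Adding Benzylamino to Compound 1

The compounds below may be only part of what the source reports. "The series", "measured", "known", "first", "only" and "open" are said of these compounds alone.

Compound 1 `Cc1noc(NS(=O)(=O)c2cccc3ccccc23)c1C` was tested in an assay on VSM-A10 cells for antagonist activity at Endothelin-1 receptor (Rattus norvegicus) (on this read-out higher numbers stand for weaker inhibition and lower numbers for stronger inhibition), where compound 1 gives 20000 nM. For the measured compounds named here, that is the higher of the two numbers measured so far, so compound 1 is the weaker inhibitor of the pair. The other measured compound, compound 2 `CCc1noc(NS(=O)(=O)c2cccc3c(N(C)C)cccc23)c1C`, gives 1170 nM in this assay; compound 2 differs from compound 1 in more than one place, so its lower number cannot be tied to any single change.

Compound 3 `Cc1noc(NS(=O)(=O)c2cccc3c(NCc4ccccc4)cccc23)c1C` has not yet been measured. It differs from compound 1 in one place only: benzylamino in place of hydrogen on an aromatic carbon. Going by the values given here, no step between measured compounds shows this exact change. Compound 2, which carries additional groups on the shared core, gives the lower value 1170 nM. Compound 3 is therefore expected to give a lower number than compound 1, a step of an 8.0-fold lower number from compound 1 to compound 3 (0.90 log units; beyond the scatter) expected to reach beyond the scatter. The estimate for compound 3 is 2500 nM, between 600 nM and 10000 nM.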

Compound 3, half-maximal inhibitory concentration: 590 nM
For compound 3 the middle estimate is 4.2-fold (0.63 log units) above the measured one, and the stated range ends above it.
By their numbers in this assay, from the lowest: compounds 3 and 2 (each within the scatter of the next); then compound 1.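

Putting benzylamino in place of hydrogen on this aromatic carbon gives a 34-fold lower number from compound 1 to compound 3 (1.53 log units; beyond the scatter) in this assay, a large step toward stronger inhibition. For the compounds shown here, this is the first effect that can be tied to a single change, since compound 2 differs from compound 1 in more than one place. It shows that this carbon of the shared core can carry a group with its own six-membered aromatic ring and that inhibition improves with it, although nothing available explains the gain.

Still open, as far as these compounds go, is how much of the benzylamino group the step requires. A plain amino group on the same carbon would test the nitrogen without the ring, while a longer chain, such as phenylethylamino, would test how the step changes when the ring sits further out.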